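Replacing chloro with amino in compound 3

The source may hold more compounds than are shown below. What is called first, only, known or untested is meant among the compounds shown, and "the series" means these compounds.

Of the compounds shown here, three have so far been measured in a functional assay on HeLa cells (Homo sapiens) for inhibition (on this read-out higher numbers stand for weaker inhibition and lower numbers for stronger inhibition), as half-maximal inhibitory concentrations. Compound 1 `CCCCc1ccc(Nc2nc(N)c3[nH]cnc3n2)cc1` gives 40000 nM on this read-out. Compound 2 `CCCCc1ccc(Nc2nc3c(ncn3[C@@H]3C[C@@H](O)[C@H](CO)O3)c(=O)[nH]2)cc1` gives 25000 nM on the same read-out. Compound 3 `CCCCc1ccc(Nc2nc(Cl)c3ncn([C@@H]4C[C@@H](O)[C@H](CO)O4)c3n2)cc1` gives 10300 nM and holds the lowest of the three numbers, with its gaps to both other compounds beyond the scatter.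

The next compound is compound 4 `CCCCc1ccc(Nc2nc(N)c3ncn([C@@H]4C[C@@H](O)[C@H](CO)O4)c3n2)cc1` which carries amino in place of chloro on an aromatic carbon, next to the ring nitrogen amino in place of chloro on an aromatic carbon with the rest of compound 3 unchanged.

Going by the values given here, no measured pair isolates this change, so its size in this assay can only be judged indirectly. Compound 1 also carries the amino group and gives 40000 nM on the read-out, but it differs from compound 4 in more than this one place. Compound 2 has neither chloro nor amino in that place and gives 25000 nM on the read-out. On these values, a modest move to a higher number, meaning weaker inhibition, is expected. The expected step is a 2.1-fold higher number from compound 3 to compound 4 (0.33 log units; beyond the scatter) in size and direction. For compound 4 the estimated value is 22000 nM with an expected range of 9000 nM to 55000 nM around it.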

Compound 4, half-maximal inhibitory concentration: 1400 nM
The estimate for compound 4 lay 16-fold (1.20 log units) above the measured number; measured number outside the range, below it.
By their numbers in this assay, from the lowest: compound 4; then compound 3; then compounds 2 and 1 (each within the scatter of the next).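

Going by these compounds alone, compound 3 and compound 4 form the first pair that differs in one place only, so the effect of this position in this assay can now be read directly. Amino in place of chloro on this aromatic carbon of the six-membered aromatic ring gives a 7.4-fold lower number from compound 3 to compound 4 (0.87 log units; beyond the scatter), showing that inhibition in this series depends on the group held here, with stronger inhibition carrying amino than carrying chloro. The swap keeps the heavy-atom count unchanged and adds one hydrogen-bond donor and one hydrogen-bond acceptor by count, but no measurement at hand links either count to the step or otherwise accounts for it.

As far as these compounds go, whether the free amino group itself is required remains open, since methylamino, dimethylamino, hydroxyl or plain hydrogen at this position would separate it from related replacements. From the compounds shown here alone, whether the step carries over to other parts of the series is also open, as compound 1 carries amino but differs from compound 4 in more than one place.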